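Nitrofuran esters: cytotoxicity of compound 3 in prospect

A few compounds are considered here, and "the series" means these few. Any claim that something is new, unique, unknown or untested is made for them only; others in the source may bear on it.

Values so far in an ADME assay on MT4 cells (Homo sapiens) for cytotoxicity, read by MTT assay, with a stated time of 3 days (on this read-out lower numbers stand for higher toxicity in this test and higher numbers for lower toxicity in this test), are these
- compound 1 (`CC(C)(NC(=O)COC(=O)c1ccc([N+](=O)[O-])o1)c1ccccc1`) gives > 100000 nM
- compound 2 (`CC(C)(C)N(CCC(=O)c1ccccc1)C(=O)COC(=O)c1ccc([N+](=O)[O-])o1`) gives "not active" (no number reported)

The entry for compound 1 is a limit of the assay and not a number (> 100000 nM). Compound 2 has no single number and stands only as "not active" (no number reported) in this assay without any figure. Compound 3 (`COc1ccc(CN(C(=O)COC(=O)c2ccc([N+](=O)[O-])o2)C(C)(C)C)cc1`) is not yet measured. The change 4-methoxyphenyl in place of benzoylmethyl on a saturated chain carbon bound to an amide-type nitrogen puts 4-methoxyphenyl in place of benzoylmethyl on a saturated chain carbon bound to an amide-type nitrogen. In this assay no step beyond the scatter is expected, in either direction. Compound 3 is estimated at 70000 nM with 20000 nM to 100000 nM as the expected range.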

Compound 3, half-maximal cytotoxic concentration: > 100000 nM
Compound 3: no number, only a limit; the forecaster's own chance of this, stated with the estimate: 60%; middle value at least 1.4-fold (0.15 log units) away from the limit.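

In this assay compound 3 gives > 100000 nM, which is a limit of the assay and not a number. Compound 2 has no number, so no step between compound 2 and compound 3 can be read: the limit of > 100000 nM in this assay, at which 2 of the 3 values shown sit.

Going by these compounds, whether 4-methoxyphenyl in place of benzoylmethyl changes the half-maximal cytotoxic concentration in this assay remains open.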